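The compounds below may be only part of what the source reports. "The series", "measured", "known", "first", "only" and "open" are said of these compounds alone.

In a functional assay on HepG2 cells (Homo sapiens) for cytotoxicity, read by MTT assay, with a stated time of 48 h (a higher number here means a weaker inhibitor, a lower number a stronger inhibitor), three compounds sharing one core have been measured so far. Compound 1 `COc1cc(/C=C/C(=O)/C=C/c2nc3ccccc3n2C)ccc1O` gives 2900 nM and compound 2 `COc1ccc(/C=C/C(=O)/C=C/c2nc3ccccc3n2C)cc1O` gives 2900 nM in this test, so the two stand level at the digits reported. Compound 3 `COc1ccc(/C=C/C(=O)/C=C/c2nc3cc(C)ccc3n2C)cc1O` gives 3300 nM and lies within the scatter of compound 2, which means that the three numbers do not separate compound 2 from the others.

Compound 4 `COc1ccc(/C=C/C(=O)/C=C/c2nc3c(C)cccc3n2C)cc1O` has not yet been measured. It differs from compound 2 by methyl in place of hydrogen on an aromatic carbon and so carries methyl in place of hydrogen on an aromatic carbon, ortho to a fused ring and meta to a fused ring. Within the data shown here, one measured step bears on this change. It is the same replacement on another aromatic carbon, a 1.1-fold higher number from compound 2 to compound 3 (0.06 log units; within the scatter), and it stays within the scatter. Among the measured compounds shown here, that is a single step, and no measurement yet shows what methyl does at the carbon that it occupies in compound 4. The expectation is therefore for no change beyond the scatter in this assay, with a wide margin left open. The estimate means a 1.1-fold higher number from compound 2 to compound 4 (0.04 log units; within the scatter) as the expected step. Compound 4 is expected at about 3200 nM in a range from 1800 nM to 5500 nM when it is tested.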

Compound 4, half-maximal inhibitory concentration: 14700 nM
Compound 4: middle estimate off by 4.6-fold (0.66 log units), on the low side, and the stated range ends below it.
By their numbers in this assay, from the lowest: compounds 1, 2 and 3 (each within the scatter of the next); then compound 4.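

In this assay, methyl in place of hydrogen on this aromatic carbon, ortho to a fused ring and meta to a fused ring, gives a 5.1-fold higher number from compound 2 to compound 4 (0.70 log units; beyond the scatter) and so moves the number towards weaker inhibition, whereas the same replacement on another aromatic carbon gives a 1.1-fold higher number from compound 2 to compound 3 (0.06 log units; within the scatter) and stays within the scatter. Among these compounds, the outcome of this replacement therefore depends on which carbon of the six-membered aromatic ring carries the methyl, which the earlier compounds, all within the scatter of one another, could not show. No measurement presented here explains why this carbon behaves differently from the other. The compounds shown leave open whether the step belongs to methyl alone or would also appear with another group at this carbon, such as fluorine, hydroxyl, an amine or a longer chain like ethyl. They also leave open whether methyl at the same carbon would give a similar step on the core of compound 1, which carries the hydroxyl and methoxy groups the other way round.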